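The source may hold more compounds than are shown below. What is called first, only, known or untested is meant among the compounds shown, and "the series" means these compounds.

Measured in a functional assay on A549 cells (Homo sapiens) for antiproliferative activity, read by luminescence and CellTiter-Glo, with a stated time of 48 h; on this read-out higher numbers stand for weaker inhibition and lower numbers for stronger inhibition:
- Compound 1 `O=C1CCC[C@@H]([C@H]2C[C@@H]2c2ccccc2)O1`: > 100000 nM, a limit of the assay and not a number
- Compound 2 `O=C1C=CC[C@H]([C@@H]2C[C@H]2c2ccccc2)O1`: 62800 nM

Within the data shown here, compound 2 carries the only actual number in this pair, as the entry for compound 1 is a limit. Compound 3 `O=C1C=CC[C@H]([C@H]2C[C@@H]2c2ccccc2)O1` departs from compound 2 by the two compounds have the same atoms and bonds and differ only in configuration as drawn: 2 of 3 stereo elements differ; a stereocentre at a saturated ring carbon is drawn R in compound 2 and S in compound 3; a stereocentre at a saturated ring carbon is drawn R in compound 2 and S in compound 3. Among the measured compounds shown here, nothing leaves or enters, and two saturated ring carbon stereocentres are drawn S rather than R. No measured pair shows what such a change does, so the expected result is a 1.0-fold lower number from compound 2 to compound 3 (0.02 log units; within the scatter), with no shift beyond the usual scatter in either direction. Compound 3 is estimated at 60000 nM, with an expected range of 20000 nM to 150000 nM.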

Compound 3, half-maximal inhibitory concentration: 11600 nM
Beside the measured number, compound 3's estimate is 5.2-fold (0.71 log units) above it, and the stated range ends above it.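

In this assay, among these compounds, the result gives a 5.4-fold lower number from compound 2 to compound 3 (0.73 log units; beyond the scatter), the first step in this set that can be read. With nothing leaving or entering, the step can be put down to the two saturated ring carbon stereocentres alone, because of this: the fact that compounds 2 and 3 differ only in the configuration as drawn

Both stereocentres change together, and the compounds shown leave open which of them carries the step. They also leave open whether an amine or a carboxylic acid on the shared core would move the number further.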